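Inverting the ring stereocentre in compound 3

The source may report more compounds than this note shows. Statements on the series, on what has been measured and on what is new or still open speak of the compounds shown alone.

Among the measured compounds shown here, compound 3 `Cc1cccc(C(=O)Nc2ccc3c(c2)C[C@@H](NS(C)(=O)=O)C3)c1-c1ccc(C(F)(F)F)cc1` stands second highest of the three numbers so far in an assay on isolated protein for inhibition of microsomal triglyceride transfer protein large subunit (Homo sapiens) (a lower number here means a stronger inhibitor, a higher number a weaker inhibitor), where compound 3 gives 204 nM. Its nearest neighbour is compound 2 `Cc1cccc(C(=O)Nc2ccc3c(c2)CC(NS(=O)(=O)c2ccccc2)C3)c1-c1ccc(F)cc1`, which in this assay gives 240 nM, within the scatter; the furthest is compound 1 `COC(=O)N[C@@H]1Cc2ccc(NC(=O)c3ccccc3-c3ccc(C(F)(F)F)cc3)cc2C1`, which gives 110 nM, also within the scatter. Compound 4 `Cc1cccc(C(=O)Nc2ccc3c(c2)C[C@H](NS(C)(=O)=O)C3)c1-c1ccc(C(F)(F)F)cc1` differs from compound 3 only in configuration: the two compounds have the same atoms and bonds and differ only in configuration as drawn: 1 of 1 stereo elements differ; a stereocentre at a saturated ring carbon is drawn S in compound 3 and R in compound 4. For the measured compounds named here, no step between measured compounds shows how this assay responds to inverting that stereocentre, so the direction rests on general expectation alone. The mirror configuration is expected to weaken binding in this assay, with a wide range, and the step is estimated as a 3.4-fold higher number from compound 3 to compound 4 (0.54 log units; beyond the scatter). Compound 4 is expected to give about 700 nM in this assay, between 150 nM and 4000 nM.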

Compound 4, half-maximal inhibitory concentration: 34 nM
Estimate against measurement, compound 4: 21-fold (1.31 log units) above, outside the stated range (below it).
By their numbers in this assay, from the lowest: compound 4; then compounds 1, 3 and 2 (each within the scatter of the next, the first and the last beyond it).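

In this assay, among the compounds shown here, the saturated ring carbon bearing the sulfonamide proves sensitive to configuration, which the earlier compounds could not show: going from S to R gives a 6.0-fold lower number from compound 3 to compound 4 (0.78 log units; beyond the scatter) within the same methylsulfonyl series. With the atoms and bonds unchanged, this step can be assigned to configuration alone: the fact that compounds 3 and 4 differ only in the configuration as drawn

As far as these compounds go, whether R remains preferred with the methyl carbamate of compound 1 or the phenylsulfonyl group of compound 2, which is drawn without configuration at this carbon, stays open. So does the response of the R form to a free amine or a carboxylic acid at this carbon.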